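Dimethylamino for Diethylamino on a Shared Core

A few compounds are considered here, and "the series" means these few. Any claim that something is new, unique, unknown or untested is made for them only; others in the source may bear on it.

Measured compounds:
compound 1 `CCN(CC)c1ccc(N2C(=O)NC3(CSC4=C3C(=O)c3ncccc3C4=O)C2=O)cc1`: 8 nM
compound 2 `O=C1C2=C(C(=O)c3ncccc31)C1(CS2)NC(=O)N(c2ccncc2)C1=O`: 3 nM
compound 3 `Cc1ccc(N2NC(=O)NC3(CSC4=C3C(=O)c3ncccc3C4=O)C2=O)cc1`: 100 nM

In a functional assay on MT4 cells (Homo sapiens) for antiproliferative activity, read by MTT assay, with a stated time of 96 h (on this read-out higher numbers stand for weaker inhibition and lower numbers for stronger inhibition), compound 1 stands second highest of the three numbers. Compound 2 gives the lower number, a gap beyond the scatter, while compound 3 gives the higher number, also beyond the scatter. No pair among these compounds differs in one place only, so no measured step guides what follows.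

Compound 4 `CN(C)c1ccc(N2C(=O)NC3(CSC4=C3C(=O)c3ncccc3C4=O)C2=O)cc1` keeps the core of compound 1, with one change: dimethylamino in place of diethylamino on an aromatic carbon. Nothing measured here tracks this change. The expectation is a small step from compound 1, most likely within the scatter or slightly upward. Compound 4 is therefore estimated at 10 nM, with a range of 4 nM to 25 nM, which means an expected step of a 1.3-fold higher number from compound 1 to compound 4 (0.10 log units; within the scatter).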

Compound 4, half-maximal inhibitory concentration: 15 nM
Compound 4: the middle estimate sits 1.5-fold (0.18 log units) below what was measured, and the stated range covers the measured number.
By their numbers in this assay, from the lowest: compound 2; then compounds 1 and 4 (each within the scatter of the next); then compound 3.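

In this assay dimethylamino in place of diethylamino gives a 1.9-fold higher number from compound 1 to compound 4 (0.27 log units; within the scatter) at this position, para to a large group, so the two groups cannot be told apart here. On the shared core, 4-(dimethylamino)phenyl in place of pyridin-4-yl on an amide-type nitrogen in a ring gives a 5.0-fold higher number from compound 2 to compound 4 (0.70 log units; beyond the scatter) and stays clearly apart. Nothing measured here bears on the cause of either step.

The compounds shown leave open how a primary amine, a morpholine ring or a methoxy group on the same aromatic carbon would read in this assay and whether dipropylamino, with its longer chains, would stay within the scatter of compound 1.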